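A few compounds are considered here, and "the series" means these few. Any claim that something is new, unique, unknown or untested is made for them only; others in the source may bear on it.

Of the compounds shown here, two have been measured in an assay for inhibition of Apoptosis regulator Bcl-2 (Homo sapiens), read by fluorescence polarization, with a stated time of 2 h; a higher number here means a weaker inhibitor, a lower number a stronger inhibitor. Compound 1 `Cc1c(C(=O)NCCCN2CCN(C)CC2)c(-c2cccc(N3CCN(c4ccc(NS(=O)(=O)c5cccc(S(=O)(=O)C6CC6)c5)cc4)CC3)c2)c(-c2ccc(Cl)cc2)n1C` gives 844 nM, and compound 2 `Cc1cccc(S(=O)(=O)Nc2ccc(N3CCN(c4cccc(-c5c(C(=O)NCCCN6CCN(C)CC6)c(C)n(C)c5-c5ccc(Cl)cc5)c4)CC3)cc2)c1` gives 689 nM. Compound 2 therefore has the lower of the two numbers, but the gap to compound 1 lies within the usual scatter: the step of a 1.2-fold lower number from compound 1 to compound 2 (0.09 log units; within the scatter) exchanged one group on an aromatic carbon without a clear effect on the read-out.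

Compound 3 `Cc1c(C(=O)NCCCN2CCN(C)CC2)c(-c2cccc(N3CCN(c4ccc(NS(=O)(=O)c5cccc(S(C)(=O)=O)c5)cc4)CC3)c2)c(-c2ccc(Cl)cc2)n1C` is the next compound in this series and has not yet been measured. It differs from compound 2 in one place: methylsulfonyl in place of methyl on an aromatic carbon. Within the data shown here, the only measured step that bears on this change is the one from compound 1 to compound 2, in which a sulfonyl-bearing group gave way to a methyl and the number hardly moved, as a 1.2-fold lower number from compound 1 to compound 2 (0.09 log units; within the scatter) shows. Going the other way, from methyl back to a sulfonyl-bearing group, is therefore expected to change little, and the step of a 1.1-fold higher number from compound 2 to compound 3 (0.05 log units; within the scatter) is expected to stay within the scatter. In this assay compound 3 is estimated at 780 nM, with a likely range from 390 nM to 1600 nM.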

Compound 3, half-maximal inhibitory concentration: 2540 nM
Compound 3: the middle estimate sits 3.3-fold (0.51 log units) below what was measured; measured number outside the range, above it.
By their numbers in this assay, from the lowest: compounds 2 and 1 (each within the scatter of the next); then compound 3.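

In this assay, this position turned out not to be indifferent to what it carries: the change to methylsulfonyl on an aromatic carbon, meta to a large group, produced a 3.7-fold higher number from compound 2 to compound 3 (0.57 log units; beyond the scatter) and so had a clear effect that the first two compounds gave no sign of. Nor do the two sulfonyl-bearing groups behave alike, since methyl in place of cyclopropyl on the sulfonyl sulfur gives a 3.0-fold higher number from compound 1 to compound 3 (0.48 log units; beyond the scatter) even though the sulfonyl itself stays, while compound 1 and compound 2, with cyclopropylsulfonyl and methyl at this place, lie within the scatter of each other. Nothing shown here explains why methylsulfonyl stands apart from both.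

Three groups at one position cannot show whether the number depends mainly on what sits on the sulfonyl sulfur, and an ethylsulfonyl or an isopropylsulfonyl group would help to settle that. As far as these compounds go, it also stays open how groups without a sulfonyl, such as an amine or a carboxylic acid, would fare at this carbon on the same core.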